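The source may report more compounds than this note shows. Statements on the series, on what has been measured and on what is new or still open speak of the compounds shown alone.

Measured so far, in a functional assay on DU-145 cells (Homo sapiens) for antiproliferative activity, read by MTT assay, with a stated time of 72 h; a higher number here means a weaker inhibitor, a lower number a stronger inhibitor:
- compound 1 `O=C(COc1ccc(C(=O)/C=C/c2ccccc2Br)cc1)N[C@H]1CCOC1=O` gives 3540 nM
- compound 2 `CC(C)(C)c1ccc(/C=C/C(=O)c2ccc(OCC(=O)N[C@H]3CCOC3=O)cc2)cc1` gives 6570 nM
- compound 3 `O=C(COc1ccc(C(=O)/C=C/c2cccc(Cl)c2)cc1)N[C@H]1CCOC1=O` gives 3700 nM

All three share one core and differ only in the aromatic ring at the end of the double-bonded chain. Compound 3 sits second highest of the three numbers, but its neighbours are close: a 1.0-fold higher number from compound 1 to compound 3 (0.02 log units; within the scatter) and a 1.8-fold lower number from compound 2 to compound 3 (0.25 log units; within the scatter), so none of the three can be told apart on these data.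

Compound 4 `O=C(COc1ccc(C(=O)/C=C/c2cccc([N+](=O)[O-])c2)cc1)N[C@H]1CCOC1=O` is the next member of this set. Compared with compound 3 the change is nitro in place of chloro on an aromatic carbon. The two steps recorded so far, a 1.0-fold higher number from compound 1 to compound 3 (0.02 log units; within the scatter) and a 1.9-fold higher number from compound 1 to compound 2 (0.27 log units; within the scatter), both swap one substituted ring for another at this same position, and neither moves the number beyond the scatter. Nothing measured here tells what a nitro group does at this place, so the best guide is that ring changes at this position have so far left the number roughly where it was.

The expectation is therefore that compound 4 lands close to compound 3, with a 1.1-fold higher number from compound 3 to compound 4 (0.03 log units; within the scatter) as the expected step in this assay. The estimate for compound 4 is 4000 nM, with a range from 1500 nM to 11000 nM.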

Compound 4, half-maximal inhibitory concentration: 41800 nM
Beside the measured number, compound 4's estimate is 10-fold (1.02 log units) below it; the measured number lies above the stated range.
By their numbers in this assay, from the lowest: compounds 1, 3 and 2 (each within the scatter of the next); then compound 4.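

In this assay, going by these compounds alone, the ring at the end of the double-bonded chain proves less forgiving than the earlier compounds suggested: nitro in place of chloro on an aromatic carbon gives an 11-fold higher number from compound 3 to compound 4 (1.05 log units; beyond the scatter), the first step in this set to lie beyond the scatter. The comparisons with the other two compounds point the same way, with a 12-fold higher number from compound 1 to compound 4 (1.07 log units; beyond the scatter) and a 6.4-fold higher number from compound 2 to compound 4 (0.80 log units; beyond the scatter), so 3-nitrophenyl separates compound 4 from the 2-bromophenyl, 3-chlorophenyl and 4-(tert-butyl)phenyl compounds, which stay within the scatter of one another. Within the data shown here, no measurement available here explains why this one change moves the number so far.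

Going by these compounds, with a single nitro compound in view, it remains open whether the nitro group would give a similarly high number at another place on the ring, or whether the result is tied to this place. On these data alone, it is also open whether an amine, a carboxylic acid or a nitrile in the same place would stay close to compound 3 or move towards compound 4.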